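Propyl in Place of Phenyl: Expecting a Small Shift

This account rests on a few compounds, and the source may have more. Where it says the series, first, only, none or still open, it means among the compounds named here.

Three compounds have been measured in a functional assay on NCI-H460 cells (Homo sapiens) for antiproliferative activity, read by CCK-8 assay, with a stated time of 72 h, tested at 8 uM; on this read-out lower numbers stand for a weaker effect and higher numbers for a stronger effect at the one concentration tested:

compound 1 `Cc1ccc(Nc2nc(Cl)nc3c2ncn3Cc2ccc(/C=C/C(=O)Nc3ccccc3N)cc2)cc1` gives 51.3%
compound 2 `Nc1ccccc1NC(=O)c1ccc(CNc2nc(Cl)nc3c2ncn3Cc2ccccc2)cc1` gives 46.4%
compound 3 `Nc1ccccc1NC(=O)c1ccc(Cn2cnc3c(NCc4ccccc4)nc(Cl)nc32)cc1` gives 61.2%

Among these, compound 2 gives the lowest of the three numbers. Its nearest neighbour is compound 1, whose number lies within the usual scatter of such measurements, so the two cannot be told apart. Compound 3 lies further off, beyond the scatter, so compound 3 shows a stronger effect than compound 2 in this assay.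

Compound 4 `CCCCn1cnc2c(NCc3ccc(C(=O)Nc4ccccc4N)cc3)nc(Cl)nc21` has not yet been measured. Relative to compound 2 it carries one change: propyl in place of phenyl on a saturated chain carbon bound to an aromatic nitrogen. Among the compounds with values here, no pair of measured compounds differs in this way, so there is no measured step to lean on. Since the parent amide and the shared core are untouched, the step of a number 1.4 percentage points lower from compound 2 to compound 4 (within the scatter) is expected to be small, with no direction that rises beyond the scatter. In this assay compound 4 is therefore expected to give about 45%, within a range from 30% to 60%.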

Compound 4, a percentage reported as inhibition, at one concentration (the size of the read-out at that concentration, not a potency): 23.7%
Compound 4: the middle estimate sits 21.3 percentage points above what was measured, and the stated range ends above it.
By their numbers in this assay, from the lowest: compound 4; then compounds 2, 1 and 3 (each within the scatter of the next, the first and the last beyond it).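

Within the data shown here, compound 4 gives the first measured step at this position: setting propyl in place of phenyl on a saturated chain carbon bound to an aromatic nitrogen brings a number 22.7 percentage points lower from compound 2 to compound 4 (beyond the scatter) in this assay at the one concentration tested. The effect in this assay therefore depends on which group sits at this position, even though neither group has a hydrogen-bond donor, a hydrogen-bond acceptor or a net charge. Nothing measured here explains why the number falls with this change.

This single step swaps a ring for an open chain and also changes the number of carbons, so it cannot show which of the two differences matters. Going by these compounds, a cyclohexyl group would keep a six-membered carbon ring without aromaticity, while a longer chain such as hexyl would restore the carbon count without any ring, and how either would read out remains open.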